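A few compounds are considered here, and "the series" means these few. Any claim that something is new, unique, unknown or untested is made for them only; others in the source may bear on it.

In a functional assay on HeLa cells (Homo sapiens) for cytotoxicity, read by MTT assay (on this read-out higher numbers stand for weaker inhibition and lower numbers for stronger inhibition), two esters sharing the same core have been measured so far. Compound 1 `CCCC(O)CC(=O)O[C@H](CC=C(C)C)C1=CC(=O)c2c(O)ccc(O)c2C1=O` gives 59300 nM, and compound 2 `CC(C)=CC[C@@H](OC(=O)C1CCOC1)C1=CC(=O)c2c(O)ccc(O)c2C1=O` gives 73500 nM. For the measured compounds named here, these two numbers lie within the scatter of each other, so compound 2 stands level with the only other compound measured, and both numbers are large on this scale.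

Compound 3 `CC(C)=CC[C@@H](OC(=O)CC(C)(O)c1ccccc1)C1=CC(=O)c2c(O)ccc(O)c2C1=O` differs from compound 2 in one group: 2-hydroxy-2-phenylpropyl in place of oxolan-3-yl on a carbonyl carbon. In short, 2-hydroxy-2-phenylpropyl comes in place of oxolan-3-yl on a carbonyl carbon.

Going by the values given here, only one measured step bears on this change: a 1.2-fold higher number from compound 1 to compound 2 (0.09 log units; within the scatter), with oxolan-3-yl in place of 2-hydroxypentyl on a carbonyl carbon. Exchanging the group at this place once left the number within the scatter, but a single step is thin evidence, and neither measured compound carries an aromatic ring in this group. No step beyond the scatter is therefore expected in this assay. The estimated step is a 1.3-fold lower number from compound 2 to compound 3 (0.13 log units; within the scatter). Compound 3 is expected to give about 55000 nM, with an estimated range from 22000 nM to 120000 nM.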

Compound 3, half-maximal inhibitory concentration: 85700 nM
Beside the measured number, compound 3's estimate is 1.6-fold (0.19 log units) below it; low and high end bracket the measured number.
By their numbers in this assay, from the lowest: compounds 1, 2 and 3 (each within the scatter of the next).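

In this assay, oxolan-3-yl, with 5 heavy atoms, gives way to 2-hydroxy-2-phenylpropyl, with 10 heavy atoms, a six-membered aromatic ring of carbon only and 1 hydrogen-bond donor, and the result is a 1.2-fold higher number from compound 2 to compound 3 (0.07 log units; within the scatter) for this change on the carbonyl carbon. Set against the 2-hydroxypentyl group of compound 1, the same change of group gives a 1.4-fold higher number from compound 1 to compound 3 (0.16 log units; within the scatter), so this position has now taken a group with an aromatic ring as well as two without one, and all three compounds remain within the scatter of one another. Nothing measured here explains why such different groups give numbers this close.

Going by these compounds, what stays open is whether any group on this carbonyl carbon can move the number beyond the scatter, for instance one carrying an amine or a carboxylic acid. All three compounds also share the same core, so they say nothing about how the number would respond to a change anywhere else in the molecule.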